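The source may hold more compounds than are shown below. What is called first, only, known or untested is meant among the compounds shown, and "the series" means these compounds.

Working notes on the diaminoquinazoline series.

Three compounds have numbers in an assay for inhibition of Dihydrofolate reductase (Rattus norvegicus); a lower number here means a stronger inhibitor, a higher number a weaker inhibitor. Compound 1 `Cc1cccc2nc(N)nc(N)c12` gives 813 nM. Compound 2 `Nc1nc(N)c2c(Cl)c(Br)ccc2n1` gives 100 nM. Compound 3 `Nc1nc(N)c2c(Cl)c(N)ccc2n1` gives 661 nM. Among these, compound 3 stands second highest; its nearest neighbour is compound 1, a gap within the scatter, so no order between compound 1 and compound 3 is claimed. For the measured compounds named here, its furthest neighbour is compound 2, and the one step in the set that runs to it, a 6.6-fold higher number from compound 2 to compound 3 (0.82 log units; beyond the scatter), is beyond the scatter and modest in size.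

Compound 4 `Nc1nc(N)c2c(Cl)cccc2n1` is the next member. The change from compound 3 to compound 4 is hydrogen in place of amino on an aromatic carbon.

Going by the values given here, no measured step matches this change; the only step in the set, amino in place of bromo from compound 2 to compound 3, shares the same site but swaps two substituents rather than removing one. Compound 1 carries a methyl in place of the chloro and no further substituent, and its number sits close to that of compound 3. Taking these together, the expected step in this assay is a 1.7-fold lower number from compound 3 to compound 4 (0.22 log units; within the scatter), small and of uncertain direction. For compound 4 the expected number in this assay is 400 nM, with a range from 130 nM to 1300 nM.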

Compound 4, half-maximal inhibitory concentration: 562 nM
Estimate against measurement, compound 4: 1.4-fold (0.15 log units) below; low and high end bracket the measured number.
By their numbers in this assay, from the lowest: compound 2; then compounds 4, 3 and 1 (each within the scatter of the next).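

Working notes, continued: in this assay the loss of the amino group on this aromatic carbon, ortho to a chloro group, cannot be read as a change (a 1.2-fold lower number from compound 3 to compound 4 (0.07 log units; within the scatter)), so hydrogen and amino are not told apart at this position. The step from the other side (a 5.6-fold higher number from compound 2 to compound 4 (0.75 log units; beyond the scatter)) lies beyond the scatter, as does the earlier one (a 6.6-fold higher number from compound 2 to compound 3 (0.82 log units; beyond the scatter)), so among these three compounds bromo is the only substituent at this position that separates itself, and neither hydrogen nor amino goes against that. At the other substituted carbon, chloro in place of methyl also lies within the scatter (a 1.4-fold lower number from compound 1 to compound 4 (0.16 log units; within the scatter)), and no measurement at hand bears on what lies behind the bromo step.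

From the compounds shown here alone, a single bromo compound carries that separation, so it remains open whether another halogen such as fluoro or iodo, or a methoxy, a nitrile or a longer chain at this position, would fall with compound 2 or with the hydrogen and amino pair. Also open, going by these compounds, is whether bromo at this position would give a step of similar size with methyl in place of the chloro.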